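The compounds below may be only part of what the source reports. "The series", "measured", "known", "first", "only" and "open" are said of these compounds alone.

Working notes on the series.

Two compounds carry numbers in a physicochemical assay for solubility, read by nephelometry, in phosphate buffer, measured as kinetic solubility, at pH 6.5; on this read-out higher numbers stand for higher solubility and lower numbers for lower solubility. Compound 1 `CNS(=O)(=O)c1ccc(-c2cnc(N)c(-c3ccc(OC)nc3)c2)cc1` gives 12.5 ug/mL in this assay. Compound 2 `COc1ccc(-c2cc(-c3ccc(C(F)(F)F)cc3)cnc2N)cn1` gives 1.6 ug/mL in this assay. For the measured compounds named here, the single step that links them, a 7.8-fold lower number from compound 1 to compound 2 (0.89 log units; beyond the scatter), is the only measured step in hand. On the numbers shown, compound 2 stands lowest of the two, with compound 1 the nearest neighbour at a higher number.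

Compound 3 `COc1ccc(-c2cc(-c3ccc(-n4cncn4)cc3)cnc2N)cn1` has not been measured in this assay. It differs from compound 2 in one place: 1H-1,2,4-triazol-1-yl in place of trifluoromethyl on an aromatic carbon. The step from compound 1 to compound 2 bears on this change in an indirect way only, since there trifluoromethyl entered in place of a group bearing hydrogen-bond acceptors and the number fell, whereas here trifluoromethyl leaves and a ring with three hydrogen-bond acceptors enters at the same place. On that one comparison a rise of modest size is expected in this assay, a 3.8-fold higher number from compound 2 to compound 3 (0.57 log units; beyond the scatter), though a single step is a thin basis. The estimate for compound 3 in this assay is 6 ug/mL, with a range from 2 ug/mL to 20 ug/mL.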

Compound 3, solubility: 6.3 ug/mL
Estimate against measurement, compound 3: 1.1-fold (0.02 log units) below; low and high end bracket the measured number.
By their numbers in this assay, from the lowest: compound 2; then compounds 3 and 1 (each within the scatter of the next).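

In this assay, the aromatic carbon para to a large group now has a second direct replacement for trifluoromethyl: 1H-1,2,4-triazol-1-yl gives a 3.9-fold higher number from compound 2 to compound 3 (0.60 log units; beyond the scatter) and so stands apart from trifluoromethyl at this place, as methylsulfamoyl does. The comparison of the two non-fluorinated groups reads a 2.0-fold lower number from compound 1 to compound 3 (0.30 log units; within the scatter) and does not separate them, so a five-membered aromatic ring with no hydrogen-bond donors and methylsulfamoyl cannot be told apart here on these numbers. Among the three compounds, compound 2 alone has steps beyond the scatter to both others, and no measurement shown accounts for the difference between the groups.

The compounds shown leave open whether the pattern extends to other kinds of group at this place, such as an amine, a carboxylic acid, a morpholine ring or a simple nitrile, any of which would test whether the ring of the triazole matters or only the loss of trifluoromethyl. They also leave open whether the same replacement gives a step of similar size when the methoxy group elsewhere on the shared core is exchanged for another group.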